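This account rests on a few compounds, and the source may have more. Where it says the series, first, only, none or still open, it means among the compounds named here.

Three compounds from the same series share one core. Compound 1 `O=C(Nc1cccc(-n2cc(-c3ccncc3)c(-c3cc(O)cc(Cl)c3)n2)c1)Nc1ccc(Cl)c(C(F)(F)F)c1` carries a free hydroxyl on one aromatic ring; in a functional assay on BT-549 cells (Homo sapiens) for inhibition, read by sulforhodamine B assay, with a stated time of 48 h, tested at 10 uM (on this read-out lower numbers stand for a stronger effect and higher numbers for a weaker effect at the one concentration tested), compound 1 gives 47.6%. Compound 2 `COc1cc(Cl)cc(-c2nn(-c3cccc(NC(=O)Nc4ccc(Cl)c(C(F)(F)F)c4)c3)cc2-c2ccncc2)c1` has that oxygen capped with a methyl, and in this assay compound 2 gives 9.81%, a change of a number 37.8 percentage points lower from compound 1 to compound 2 (beyond the scatter). Compound 3 `COc1cc(Cl)cc(-c2nn(-c3cccc(NC(=O)Nc4cc(C(F)(F)F)cc(C(F)(F)F)c4)c3)cc2-c2ccncc2)c1` keeps the methyl on the oxygen and bears two trifluoromethyl groups on the urea-linked ring; in this assay compound 3 gives 6.61%. That is the lowest of the three numbers, yet compound 2 lies within the scatter of it, so the two cannot be ranked; only compound 1 stands clearly apart.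

Compound 4 `COc1cc(Cl)cc(-c2nn(-c3cccc(NC(=O)Nc4cccc(C(F)(F)F)c4)c3)cc2-c2ccncc2)c1` differs from compound 3 by hydrogen in place of trifluoromethyl on an aromatic carbon. For the measured compounds named here, no measured step touches this part of the molecule: the single step concerns the oxygen on the other ring, and compounds 2 and 3, which differ on the urea-linked ring, show numbers within the scatter of each other. A step of a number 8.4 percentage points higher from compound 3 to compound 4 (within the scatter) is therefore expected, small and uncertain in direction. Compound 4 is estimated at 15%, within 3% to 40%.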

Compound 4, a percentage reported as activity, at one concentration (the size of the read-out at that concentration, not a potency): 12.9%
For compound 4 the middle estimate is 2.1 percentage points above the measured one, and the stated range covers the measured number.
By their numbers in this assay, from the lowest: compounds 3, 2 and 4 (each within the scatter of the next); then compound 1.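

In this assay, hydrogen in place of trifluoromethyl gives a number 6.3 percentage points higher from compound 3 to compound 4 (within the scatter), and hydrogen in place of chloro gives a number 3.1 percentage points higher from compound 2 to compound 4 (within the scatter). On the urea-linked ring, then, the read-out at this one concentration does not separate compound 4, which keeps a single trifluoromethyl group and has hydrogen at the place meta to it, from compound 2 or compound 3, which carry a second halogen-bearing substituent. No measurement shown here explains why these changes leave the number within the scatter.

Still open, as far as these compounds go, is whether an amine or a carboxylic acid on this ring would keep the number in the same range. From the compounds shown here alone, it is also open whether an ethyl group on the oxygen of the other ring, in place of the methyl, would do the same.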